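Demethylation at the shared core: what to expect for compound 3

The compounds below may be only part of what the source reports. "The series", "measured", "known", "first", "only" and "open" are said of these compounds alone.

Measured so far:
compound 1 `COc1cc(-c2nn(-c3cccc(NC(=O)Nc4ccc(Cl)c(C(F)(F)F)c4)c3)cc2-c2ccncc2)ccc1Cl` — 1200 nM
compound 2 `COc1cc(-c2nn(-c3cccc(NC(=O)c4ccccc4)c3)cc2-c2ccncc2)ccc1Cl` — 3860 nM

In a functional assay on SK-MEL-28 cells (Homo sapiens) for inhibition, read by sulforhodamine B assay, with a stated time of 48 h (a lower number here means a stronger inhibitor of growth, a higher number a weaker inhibitor of growth), compound 1 holds the lower of the two numbers; compound 2, with phenyl in place of (4-chloro-3-(trifluoromethyl)phenyl)amino on a carbonyl carbon, stands a 3.2-fold higher number from compound 1 to compound 2 (0.51 log units; beyond the scatter). Compound 3 `O=C(Nc1cccc(-n2cc(-c3ccncc3)c(-c3ccc(Cl)c(O)c3)n2)c1)Nc1ccc(Cl)c(C(F)(F)F)c1` differs from compound 1 by hydrogen in place of methyl on an oxygen on an aromatic ring, that is methoxy to hydroxy. For the measured compounds named here, no measured step touches that oxygen; the one known step concerns the urea end only, so it gives no direction for this change. A step within the scatter is therefore expected, with a 1.1-fold higher number from compound 1 to compound 3 (0.03 log units; within the scatter) as the estimate. Compound 3 is expected to give 1300 nM, between 500 nM and 3500 nM.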

Compound 3, concentration for 50% growth inhibition: 978 nM
Compound 3: the middle estimate sits 1.3-fold (0.12 log units) above what was measured; the measured number falls inside the stated range.
By their numbers in this assay, from the lowest: compounds 3 and 1 (each within the scatter of the next); then compound 2.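

In this assay, hydrogen in place of methyl on the oxygen on the aromatic ring gives a 1.2-fold lower number from compound 1 to compound 3 (0.09 log units; within the scatter), so this step, the first to touch that oxygen, does not separate methoxy from hydroxy. With the urea end of compound 1 kept, the methyl is thus not required for growth inhibition at this level. Nothing available explains this result. Going by these compounds, how an amine or a longer alkoxy chain would read at this place stays open. Also open, on these data alone, is whether methoxy to hydroxy reads the same with the benzamide end of compound 2.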